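A few compounds are considered here, and "the series" means these few. Any claim that something is new, unique, unknown or untested is made for them only; others in the source may bear on it.

Compound 1, `Cc1cc(N2CC[C@@H](C)[C@@H](N(C)c3ncnc4[nH]ccc34)C2)n2ncnc2n1`: 67400 nM
Compound 2, `Cc1cc(N2CC[C@@H](C)[C@@H](N(C)c3ncnc4[nH]ccc34)C2)n2nc(SCc3ccc(C(F)(F)F)cc3)nc2n1`: 23300 nM
Compound 3, `Cc1cc(N2CC[C@@H](C)[C@@H](N(C)c3ncnc4[nH]ccc34)C2)n2nc(SCCc3ccccc3)nc2n1`: 28000 nM

All three numbers come from a functional assay on BGC-823 cells (Homo sapiens) for inhibition, read by MTT assay, with a stated time of 72 h; on this read-out higher numbers stand for weaker inhibition and lower numbers for stronger inhibition. Compound 3 has the second highest of the three; its nearest neighbour is compound 2, which lies within the scatter, and its furthest is compound 1, whose gap is beyond the scatter. Compound 4, `Cc1cc(N2CC[C@@H](C)[C@@H](N(C)c3ncnc4[nH]ccc34)C2)n2nc(SCc3ccc(F)c(Cl)c3)nc2n1`, differs from compound 3 at one point: 3-chloro-4-fluorophenyl in place of benzyl on a saturated chain carbon bound to a sulfur. The step that bears on this is the one that also swapped the group on the saturated chain carbon bound to the sulfur, a 1.2-fold higher number from compound 2 to compound 3 (0.08 log units; within the scatter), which stayed within the scatter. Attaching either sulfur-linked group to the shared core gave a 2.9-fold lower number from compound 1 to compound 2 (0.46 log units; beyond the scatter) and a 2.4-fold lower number from compound 1 to compound 3 (0.38 log units; beyond the scatter). Since the earlier swap at this carbon showed no shift beyond the scatter, the expected step is a 1.3-fold lower number from compound 3 to compound 4 (0.10 log units; within the scatter). Compound 4 is estimated at 22000 nM, within a range of 10000 nM to 50000 nM.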

Compound 4, half-maximal inhibitory concentration: 98900 nM
Beside the measured number, compound 4's estimate is 4.5-fold (0.65 log units) below it; the whole stated range lies below it.
By their numbers in this assay, from the lowest: compounds 2 and 3 (each within the scatter of the next); then compounds 1 and 4 (each within the scatter of the next).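

The group on the saturated chain carbon bound to a sulfur can matter after all: 3-chloro-4-fluorophenyl gives a 3.5-fold higher number from compound 3 to compound 4 (0.55 log units; beyond the scatter) and a 4.2-fold higher number from compound 2 to compound 4 (0.63 log units; beyond the scatter), whereas the earlier swap here stayed within the scatter. Adding a sulfur-linked group to the shared core does not always help, since this one gives a 1.5-fold higher number from compound 1 to compound 4 (0.17 log units; within the scatter) and so lacks the gain seen with compound 2 and compound 3. No available evidence explains the change. Whether the chlorine or the fluorine accounts for it remains open. So does how a plain benzyl, or a chain ending in an amine, would behave here.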